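Aryl piperazine succinimides: chloro to hydrogen step

The source may report more compounds than this note shows. Statements on the series, on what has been measured and on what is new or still open speak of the compounds shown alone.

Measured compounds in a functional assay on the whole organism (strain Swiss) with Mus musculus as the target, in the maximal electroshock model, with a stated time of 0.5 h, at a dose of 300 mg/kg by the intraperitoneal route; on this read-out higher numbers stand for a stronger effect at the one dose given and lower numbers for a weaker effect:
compound 1, `CC(C(=O)N1CCN(c2cccc(Cl)c2)CC1)N1C(=O)CCC1=O`: 100%
compound 2, `CCC(C(=O)N1CCN(c2cccc(OC)c2)CC1)N1C(=O)CCC1=O`: 0%
compound 3, `CCC(C(=O)N1CCN(c2cccc(C)c2)CC1)N1C(=O)CCC1=O`: 100%

Compound 1 stands level with compound 3 at the digits shown, the two together giving the highest numbers of the three, while compound 2 lies far lower. The next compound is compound 4, `CC(C(=O)N1CCN(c2ccccc2)CC1)N1C(=O)CCC1=O`, with hydrogen in place of chloro on an aromatic carbon. Within the data shown here, no measured step takes a group off this aromatic carbon, so nothing bears on the change directly. Among the measured compounds shown here, the one measured step, a number 100 percentage points higher from compound 2 to compound 3 (beyond the scatter), only shows that the choice of group at this carbon alone can move the read-out across its whole span. Because compound 1 gives 100%, a drop is expected for compound 4 but with wide uncertainty, a number 30 percentage points lower from compound 1 to compound 4 (beyond the scatter). Compound 4 is expected at 70%, range 20% to 100%.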

Compound 4, a percentage reported as activity, at one dose (the size of the read-out at that dose, not a potency): 50%
Estimate against measurement, compound 4: 20 percentage points above; low and high end bracket the measured number.
By their numbers in this assay, from the lowest: compound 2; then compound 4; then compounds 1 and 3 (each within the scatter of the next).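

In this assay, among these compounds, hydrogen in place of chloro gives a number 50 percentage points lower from compound 1 to compound 4 (beyond the scatter) and so provides the first direct reading of taking a group off this aromatic carbon. Compound 4 keeps part of the read-out without any group there, so chloro is not required for some effect at this dose, though its loss counts beyond the scatter. Nothing at hand explains the size of this step.

Open, on these data alone, is how bromo, an amine or a carboxylic acid on this aromatic carbon would compare with chloro and hydrogen.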